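Chloro on the aryl ring of compound 3

This account rests on a few compounds, and the source may have more. Where it says the series, first, only, none or still open, it means among the compounds named here.

The series is read in a functional assay on WiDr cells (Homo sapiens) for inhibition, read by sulforhodamine B assay, with a stated time of 48 h; a lower number here means a stronger inhibitor of growth, a higher number a weaker inhibitor of growth. Compound 3 `O=C(/C(=C/c1ccccc1)CCl)c1ccccc1` gives 18000 nM in this assay. Compound 1 `O=C(/C=C/c1ccc(Cl)cc1Cl)c1ccccc1` gives 20000 nM, and compound 2 `O=C(/C(=C/C1CCCCC1)CCl)c1ccccc1` gives 22000 nM; both of these numbers sit within the scatter of that of compound 3, so no order among the three compounds can be stated. Within the data shown here, the single one-place step measured so far, a 1.2-fold lower number from compound 2 to compound 3 (0.09 log units; within the scatter), is within the scatter. Compound 4 `O=C(/C(=C/c1ccc(Cl)cc1)CCl)c1ccccc1` differs from compound 3 by chloro in place of hydrogen on an aromatic carbon. Among the measured compounds shown here, no measured step bears directly on this change: compound 1 also carries chloro on its aryl ring, but it differs from compound 3 in more than one place, and its value and that of compound 3 are within the scatter of each other. With nothing in the measured steps pointing either way, the expected step is no change at the digits printed from compound 3 to compound 4 (within the scatter), within the scatter. The estimate for compound 4 in this assay is 18000 nM, within a range of 8000 nM to 40000 nM.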

Compound 4, concentration for 50% growth inhibition: 19000 nM
For compound 4 the middle estimate is 1.1-fold (0.02 log units) below the measured one; the measured number falls inside the stated range.
By their numbers in this assay, from the lowest: compounds 3, 4, 1 and 2 (each within the scatter of the next).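

In this assay chloro in place of hydrogen on an aromatic carbon, para to a large group, gives a 1.1-fold higher number from compound 3 to compound 4 (0.02 log units; within the scatter) and so leaves the number unmoved beyond the scatter. Among these compounds, this is the first one-place step read on a substituent of this ring, since the earlier step exchanged the whole cyclohexyl for phenyl; a single chloro at this place therefore gives no readable gain or loss in growth inhibition. Nothing available explains this outcome.

From the compounds shown here alone, whether an amine, a methoxy group or a carboxylic acid at the same place would move the number beyond the scatter remains open. Also open, going by these compounds, is what a longer chain in place of the chloromethyl group on the shared core would do in this assay series.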